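The source may report more compounds than this note shows. Statements on the series, on what has been measured and on what is new or still open speak of the compounds shown alone.

Measured so far in a functional assay on HCT-15 cells (Homo sapiens) for cytotoxicity, read by MTT assay, with a stated time of 2 days; on this read-out lower numbers stand for stronger inhibition and higher numbers for weaker inhibition:
Compound 1 `Cc1ccc2nc(-c3cccc(OC(F)(F)F)c3)[nH]c(=O)c2c1`: > 50000 nM, a limit of the assay rather than a number.
Compound 2 `Cc1ccc2nc(-c3ccccc3C(F)(F)F)[nH]c(=O)c2c1`: > 50000 nM, again a limit of the assay.
Compound 3 `COc1cccc(-c2nc3ccc(N4CCCCC4)cc3c(=O)[nH]2)c1OC`: 24800 nM.

Compound 2 therefore stands at the limit of > 50000 nM in this assay, at which 2 of the 3 values shown sit; only compound 3 gives a measured number, and that one is far from potent. Among the compounds with values here, no pair of measured compounds differs in a single place, so no measured step guides the change to compound 4 `Cc1ccc2nc(-c3ccccc3C)[nH]c(=O)c2c1`, which differs from compound 2 by methyl in place of trifluoromethyl on an aromatic carbon. With compound 2 at the limit, the expected step is a number no higher from compound 2 to compound 4 (the limit leaves the size open), none beyond the scatter in either direction. Compound 4 is estimated at 50000 nM, in a range from 20000 nM to 120000 nM, most likely reported only as a limit again.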

Compound 4, half-maximal inhibitory concentration: 11700 nM
The estimate for compound 4 lay 4.3-fold (0.63 log units) above the measured number, outside the stated range (below it).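

Methyl in place of trifluoromethyl on an aromatic carbon, ortho to a large group, gives an at least 4.2-fold lower number from compound 2 to compound 4 (0.63 log units; beyond the scatter) in this assay. This first measured step shows that the read-out responds to the group at this place, so the substituent there is not neutral for cytotoxicity on these cells. The value for compound 2 is a limit of the assay, not a number: the limit of > 50000 nM in this assay, at which 2 of the 4 values shown sit.

The compounds shown leave open how hydrogen, chlorine, methoxy or an amine would read at this place. They also leave open whether the same change would give a similar step on the core of compound 3.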